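The source may hold more compounds than are shown below. What is called first, only, known or untested is meant among the compounds shown, and "the series" means these compounds.

Working notes on the series, read in an ADME assay on the whole organism (plasma) for pharmacokinetics, with Rattus norvegicus as the target; a higher number here means faster removal of the compound, a lower number slower removal. Compound 1 (`O=S(=O)(c1ccc(C(F)(F)F)cc1)c1cc(F)c(O)c2ncccc12`) gives 13 mL/min/kg. Compound 2 (`O=S(=O)(c1ccc(F)cc1)c1cc(Cl)c(O)c2ncccc12`) gives 0.31 mL/min/kg, the lower of the two numbers, and its gap to compound 1 lies beyond the scatter. Compound 3 (`O=S(=O)(c1ccc(F)cc1)c1cc(F)c(O)c2ncccc12`) is still unmeasured. It departs from compound 2 in one place, with fluoro in place of chloro on an aromatic carbon, ortho to a hydroxy group: fluoro in place of chloro on an aromatic carbon. Within the data shown here, no measured pair isolates this exchange, since compound 1 and compound 2 differ in more than one place. Among the measured compounds shown here, the only guide is that compound 3 shares the fluoro with compound 1, which gives 13 mL/min/kg. On these data alone, how much of the gap between the two measured compounds goes with this exchange is unknown, so only part of it is expected to appear here. The expected change is a moderate rise beyond the scatter, a 6.5-fold higher number from compound 2 to compound 3 (0.81 log units; beyond the scatter), although a result close to the lower measured number cannot be ruled out. Compound 3 is estimated at 2 mL/min/kg, with an expected range of 0.4 mL/min/kg to 10 mL/min/kg.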

Compound 3, clearance: 12 mL/min/kg
Compound 3: the middle estimate sits 6.0-fold (0.78 log units) below what was measured, and the stated range ends below it.
By their numbers in this assay, from the lowest: compound 2; then compounds 3 and 1 (each within the scatter of the next).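

In this assay, the exchange of chloro for fluoro on the aromatic carbon ortho to a hydroxy group is now isolated, and on its own it gives a large step: a 39-fold higher number from compound 2 to compound 3 (1.59 log units; beyond the scatter). Among these compounds, the single exchange elsewhere, fluoro in place of trifluoromethyl on an aromatic carbon, gives a 1.1-fold lower number from compound 1 to compound 3 (0.03 log units; within the scatter), so among the steps available, only the one at the carbon ortho to the hydroxy group lies beyond the scatter, and the number proves sensitive to a one-atom exchange at that position. Nothing at hand gives a reason for the size of this step.

Still open, on these data alone, is whether the low number goes with chloro alone or would also hold for other groups on the same carbon, such as bromo, methyl or nitrile. Also open, as far as these compounds go, is whether the exchange of fluoro for trifluoromethyl would stay within the scatter with chloro rather than fluoro ortho to the hydroxy group, since that step is read only with fluoro there.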